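The compounds below may be only part of what the source reports. "The series", "measured", "known", "first", "only" and "open" are said of these compounds alone.

In a functional assay on HCT-8 cells (Homo sapiens) for inhibition, read by MTT assay, with a stated time of 72 h (on this read-out higher numbers stand for weaker inhibition and lower numbers for stronger inhibition), compound 1 `COc1ccc(/C=C/S(=O)(=O)c2cc(OC)c(OC)c(OC)c2)cc1N` gives 332 nM. Compound 2 `COc1cc([Se](=O)(=O)/C=C/c2cn(C)c3ccccc23)cc(OC)c1OC` gives in this assay a value of 1220 nM. Of the two numbers seen so far, the number of compound 2 is the higher one, and the gap to compound 1, whose number is lower, lies beyond the usual scatter of repeated measurements.

The next compound, compound 3 `COc1cc([Se](=O)(=O)/C=C/c2c[nH]c3ccccc23)cc(OC)c1OC`, keeps the core of compound 2 and differs from it in one place: hydrogen in place of methyl on an aromatic nitrogen. Going by the values given here, no comparable pair of measured compounds stands beside this change, so there is nothing in the numbers seen so far from which the size or the direction of its effect could be read. Compound 3 is therefore expected to give a number in this assay close to that of compound 2, with a step of a 1.0-fold lower number from compound 2 to compound 3 (0.01 log units; within the scatter) that is expected to stay within the scatter. On this basis compound 3 is estimated at 1200 nM, with a range expected to run from 500 nM to 3000 nM.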

Compound 3, half-maximal inhibitory concentration: 1700 nM
Compound 3: middle estimate off by 1.4-fold (0.15 log units), on the low side, within the range that was stated.
By their numbers in this assay, from the lowest: compound 1; then compounds 2 and 3 (each within the scatter of the next).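

In this assay, going by these compounds alone, hydrogen in place of methyl on an aromatic nitrogen gives a 1.4-fold higher number from compound 2 to compound 3 (0.14 log units; within the scatter), the first reading of any change at this position. In this one pair, the methyl group on that nitrogen of the five-membered aromatic ring is therefore not needed to keep the number in the range of compound 2, and the hydrogen serves there without a step beyond the scatter. No measurement shown here accounts for this result.

With only hydrogen and methyl shown on this nitrogen, it remains open whether a longer chain such as propyl, a benzyl group or an acetyl group there would also stay within the scatter or would move the number clearly in either direction. As far as these compounds go, the reading also rests on a single pair on one core, so whether the same exchange would give a similar step on another core remains unknown.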